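Para-methyl to para-methoxy on the pendant phenyl

This account rests on a few compounds, and the source may have more. Where it says the series, first, only, none or still open, it means among the compounds named here.

Measured so far in an assay on isolated protein for binding affinity to Adrenergic receptor alpha-1 (Homo sapiens); on this read-out lower numbers stand for stronger inhibition and higher numbers for weaker inhibition:
- compound 1 `COc1ccccc1N1CCN(CCn2c(=O)[nH]c3[nH]c(-c4ccccc4)cc3c2=O)CC1`: 1.99 nM
- compound 2 `COc1ccccc1-c1cc2c(=O)n(CCN3CCN(c4ccccc4OC)CC3)c(=O)[nH]c2[nH]1`: 1.63 nM
- compound 3 `COc1ccccc1N1CCN(CCn2c(=O)[nH]c3[nH]c(-c4ccc(C)cc4)cc3c2=O)CC1`: 4.97 nM

Compound 3 gives the highest number of the three in this assay, with a 2.5-fold higher number from compound 1 to compound 3 (0.40 log units; beyond the scatter) and a 3.0-fold higher number from compound 2 to compound 3 (0.48 log units; beyond the scatter); compounds 1 and 2 sit within the scatter of each other, a 1.2-fold lower number from compound 1 to compound 2 (0.09 log units; within the scatter).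

Compound 4 `COc1ccc(-c2cc3c(=O)n(CCN4CCN(c5ccccc5OC)CC4)c(=O)[nH]c3[nH]2)cc1` is not yet measured. The change from compound 3 is methoxy in place of methyl on an aromatic carbon. Going by the values given here, the steps that bear on it are those placing a group on this ring: the methyl that gave a 2.5-fold higher number from compound 1 to compound 3 (0.40 log units; beyond the scatter) and the methoxy that gave a 1.2-fold lower number from compound 1 to compound 2 (0.09 log units; within the scatter). The methoxy-bearing compounds 1 and 2 show no shift beyond the scatter between them, so for compound 4 a small step back toward compound 1 is expected, a 1.4-fold lower number from compound 3 to compound 4 (0.15 log units; within the scatter), though nothing in the series fixes its size. Compound 4 is therefore estimated at 3.5 nM, range 1.5 nM to 8 nM.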

Compound 4, inhibition constant: 5.47 nM
Compound 4: middle estimate off by 1.6-fold (0.19 log units), on the low side; low and high end bracket the measured number.
By their numbers in this assay, from the lowest: compounds 2 and 1 (each within the scatter of the next); then compounds 3 and 4 (each within the scatter of the next).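

In this assay, methoxy and methyl on this carbon, para to a large group, cannot be told apart: a 1.1-fold higher number from compound 3 to compound 4 (0.04 log units; within the scatter). Methoxy in place of hydrogen here gives a 2.7-fold higher number from compound 1 to compound 4 (0.44 log units; beyond the scatter), so the rise seen with methyl is not confined to that group. Placement of the methoxy matters, with 4-methoxyphenyl in place of 2-methoxyphenyl giving a 3.4-fold higher number from compound 2 to compound 4 (0.53 log units; beyond the scatter).

No available evidence accounts for this difference. From the compounds shown here alone, whether an amine or a carboxylic acid on this carbon would give a number like those of methyl and methoxy remains open.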